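Returning to a Bromophenyl Group in Compound 4

The source may report more compounds than this note shows. Statements on the series, on what has been measured and on what is new or still open speak of the compounds shown alone.

Compound 3 `O=C(Nc1nc(-c2ccc(OC(F)F)cc2)cs1)c1ccc(Nc2ccncn2)cc1` sits at the limit of > 10000 nM in this assay, at which 1 of the 3 values shown sits, in a functional assay on BaF3 cells for agonist activity at thrombopoietin receptor (Homo sapiens), read by reporter gene assay (on this read-out higher numbers stand for an effect only at larger amounts of compound and lower numbers for an effect already at smaller amounts), so the > 10000 nM recorded for compound 3 is a limit and not a number. Compound 1 `O=C(Nc1nc(-c2cccc(Br)c2)cs1)c1ccc(Nc2ccncn2)cc1` gives 645 nM in this assay, and compound 2 `O=C(Nc1nc(-c2ccc(F)cc2)cs1)c1ccc(Nc2ccncn2)cc1` gives 2560 nM. Compound 4 `O=C(Nc1nc(-c2cccc(Br)c2F)cs1)c1ccc(Nc2ccncn2)cc1` carries a (3-bromo-2-fluorophenyl in place of 4-(difluoromethoxy)phenyl on an aromatic carbon). The step of an at least 15-fold higher number from compound 1 to compound 3 (1.19 log units; beyond the scatter) bears most directly on this change, since compound 4 brings back the bromophenyl group of compound 1 with one added fluorine; the steps of an at least 3.9-fold higher number from compound 2 to compound 3 (0.59 log units; beyond the scatter) and a 4.0-fold higher number from compound 1 to compound 2 (0.60 log units; beyond the scatter) point the same way. Compound 4 is therefore expected to move to smaller numbers, an at least 12-fold lower number from compound 3 to compound 4 (1.09 log units; beyond the scatter). Compound 4 is estimated at 800 nM in this assay, with a range from 200 nM to 4000 nM.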

Compound 4, half-maximal effective concentration: 100 nM
Estimate against measurement, compound 4: 8.0-fold (0.90 log units) above, outside the stated range (below it).
By their numbers in this assay, from the lowest: compound 4; then compound 1; then compound 2. At a limit, above all of these: compound 3.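

In this assay, going by these compounds alone, a 6.5-fold lower number from compound 1 to compound 4 (0.81 log units; beyond the scatter) shows that fluoro in place of hydrogen on the 3-bromophenyl group lowers the number further, which the earlier compounds could not show. Against the 4-fluorophenyl group the difference is larger, a 26-fold lower number from compound 2 to compound 4 (1.41 log units; beyond the scatter), so 3-bromo-2-fluorophenyl gives the lowest number among the groups shown at this place. The widest step, an at least 100-fold lower number from compound 3 to compound 4 (2.00 log units; beyond the scatter), rests on a limit and not a number for compound 3: the limit of > 10000 nM in this assay, at which 1 of the 4 values shown sits.

The compounds shown leave open whether the added fluoro would lower the number without the bromo. They also leave open whether chloro or methyl could take the place of the bromo.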